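The source may hold more compounds than are shown below. What is called first, only, known or untested is meant among the compounds shown, and "the series" means these compounds.

Working notes on the series, with all numbers from an in vivo ADME assay on the whole organism (strain 129/SvEvBrd x C57BL/6) for pharmacokinetics, with Mus musculus as the target, at a dose of 1 mg/kg by the intravenous route; a lower number here means slower removal, a higher number faster removal of the compound. Of the compounds shown here, three have been measured so far. Compound 1 `CC(=O)c1ncc([C@@H](O)[C@H](O)[C@H](O)CO)s1` gives 11.7 mL/min/kg, compound 2 `CC(O)c1nc([C@@H](O)[C@H](O)[C@H](O)CO)c[nH]1` gives 16.4 mL/min/kg, and compound 3 `CC(=O)N/N=C(\C)c1nc([C@@H](O)[C@H](O)[C@H](O)CO)c[nH]1` gives 8.9 mL/min/kg. The numbers for compound 1 and compound 3 both lie within the scatter of the number for compound 2, so compound 2 holds no separate place among the three. Within the data shown here, no pair of measured compounds differs in only one place, so the effect of a single change in this assay has not been observed directly.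

Compound 4 `OC[C@@H](O)[C@@H](O)[C@H](O)c1c[nH]c(-c2cnccn2)n1` has not yet been measured. Compared with compound 2, it has pyrazin-2-yl in place of 1-hydroxyethyl on an aromatic carbon, between two ring nitrogen atoms: pyrazin-2-yl in place of 1-hydroxyethyl on an aromatic carbon. Compound 2 at 16.4 mL/min/kg and compound 3 at 8.9 mL/min/kg carry different groups at this place and remain within the scatter of each other. On that limited basis, no change beyond the scatter is expected in this assay, and no direction can be firmly assigned. The expected 1.4-fold lower number from compound 2 to compound 4 (0.14 log units; within the scatter) stays within the scatter. For compound 4 the estimated clearance is 12 mL/min/kg, with an expected range of 6 mL/min/kg to 24 mL/min/kg.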

Compound 4, clearance: 13.4 mL/min/kg
Compound 4: middle estimate off by 1.1-fold (0.05 log units), on the low side; measured number inside the range.
By their numbers in this assay, from the lowest: compounds 3, 1, 4 and 2 (each within the scatter of the next).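

In this assay, among these compounds, the exchange of 1-hydroxyethyl for pyrazin-2-yl on an aromatic carbon, between two ring nitrogen atoms, gives a 1.2-fold lower number from compound 2 to compound 4 (0.09 log units; within the scatter), and this is the first direct reading of a single change. At this place, then, a group with no ring, 3 heavy atoms and 1 hydrogen-bond donor can give way to a six-membered aromatic ring with 6 heavy atoms and 0 hydrogen-bond donors without a step beyond the scatter in clearance. No measurement at hand bears on why the step stays this small.

Among the compounds shown here, the single step covers only one pair of groups, so it remains open whether a carboxylic acid or a primary amine at this place, or a phenyl ring with no ring nitrogen, would give a step beyond the scatter. As far as these compounds go, it is also open whether pyrazin-2-yl would give a similar step on the core of compound 1, and a step read on one core does not settle that.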